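This account rests on a few compounds, and the source may have more. Where it says the series, first, only, none or still open, it means among the compounds named here.

Compound 1 `COc1ccc(/C=C/C(=O)c2cccc(-c3cccc(F)c3)c2)cc1` is the parent of this small set. In an assay on A549 cells for inhibition of transcription factor p65 (Homo sapiens), read by fluorescence, with a stated time of 2 h (on this read-out higher numbers stand for weaker inhibition and lower numbers for stronger inhibition), compound 1 gives only a limit, > 50000 nM, so its standing cannot be placed more closely than that (the limit of > 50000 nM in this assay, at which 1 of the 3 values shown sits). Compound 2 `COc1ccc(/C=C/C(=O)c2cccc(-c3cccc(F)c3)c2)cc1OC` gives 33400 nM and compound 3 `COc1ccc(/C=C/C(=O)c2cccc(-c3cccc(F)c3)c2)cc1O` gives 9590 nM; the steps of an at least 1.4-fold lower number from compound 1 to compound 2 (0.17 log units; that floor lies within the scatter) and an at least 5.2-fold lower number from compound 1 to compound 3 (0.71 log units; beyond the scatter) concern a different aromatic carbon and say nothing about the change to compound 4 `O=C(/C=C/c1ccc(Cl)cc1)c1cccc(-c2cccc(F)c2)c1`, which is chloro in place of methoxy on an aromatic carbon. For the measured compounds named here, no measured step touches this position, so the expectation rests only on compound 1 sitting at the limit: a step of an at least 1.1-fold lower number from compound 1 to compound 4 (0.04 log units; that floor lies within the scatter) is expected, with compound 4 estimated at 45000 nM, between 12000 nM and 150000 nM, most likely again reported as a limit.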

Compound 4, half-maximal inhibitory concentration: 24400 nM
The estimate for compound 4 lay 1.8-fold (0.27 log units) above the measured number; the range from low to high includes it.
By their numbers in this assay, from the lowest: compound 3; then compounds 4 and 2 (each within the scatter of the next). At a limit, above all of these: compound 1.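

For the compounds shown here, the first measured change at this position, para to a large group, shows that it is not silent in this assay: 4-methoxyphenyl to 4-chlorophenyl gives an at least 2.0-fold lower number from compound 1 to compound 4 (0.31 log units; beyond the scatter). The methoxy is therefore not required for a measurable value on the shared core. Compound 1 stands at a limit, so this step is a floor and its true size stays unknown: the limit of > 50000 nM in this assay, at which 1 of the 4 values shown sits.

Open, going by these compounds, is how an amine, a carboxylic acid or a longer chain such as butoxy would read on this carbon. Also open, on these data alone, is whether chloro here would combine with the hydroxy of compound 3.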